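The source may hold more compounds than are shown below. What is called first, only, known or untested is meant among the compounds shown, and "the series" means these compounds.

Of the compounds shown here, three sharing one core have been measured in an assay for inhibition of serine/threonine-protein kinase PAK 4 (Homo sapiens), read by FRET and Z'-LYTE, with a stated time of 60 min, tested at 50 uM, in the presence of a further agent that is not named here; on this read-out lower numbers stand for a weaker effect and higher numbers for a stronger effect at the one concentration tested. Compound 1 `CC(C)C(=O)OCOC(=O)N1CCN(C(=O)c2nc(Nc3cc(C4CC4)[nH]n3)c3cc(Cl)ccc3n2)C[C@H]1C` gives 86.9% and stands second highest of the three. Compound 3 `COC(=O)N1CCN(C(=O)c2nc(Nc3cc(C4CC4)[nH]n3)c3cc(Cl)ccc3n2)C[C@H]1C` gives 98.5%, and compound 2 `CC(OC(=O)N1CCN(C(=O)c2nc(Nc3cc(C4CC4)[nH]n3)c3cc(Cl)ccc3n2)C[C@H]1C)OC(=O)C(C)(C)C` gives 65.3%. The steps among them all lie beyond the scatter: a number 11.6 percentage points higher from compound 1 to compound 3 (beyond the scatter), a number 21.6 percentage points lower from compound 1 to compound 2 (beyond the scatter), and a number 33.2 percentage points higher from compound 2 to compound 3 (beyond the scatter).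

Compound 4 `C[C@@H]1CN(C(=O)c2nc(Nc3cc(C4CC4)[nH]n3)c3cc(Cl)ccc3n2)CCN1C(=O)OCC(Cl)(Cl)Cl` has not yet been measured. It differs from compound 1 in one place: trichloromethyl in place of (isopropylcarbonyl)oxy on a saturated chain carbon bound to an oxygen next to a carbonyl group. The group that enters is smaller than the one that leaves, with fewer heavy atoms and no hydrogen-bond acceptors.

Among the measured steps, the one from compound 1 to compound 3 bears most closely, since there too the leaving group was removed from the same position and the read-out rose modestly. The step from compound 1 to compound 2, where a bulkier group entered, went the other way. A small rise or no step beyond the scatter is therefore expected, a number 2.1 percentage points higher from compound 1 to compound 4 (within the scatter). Compound 4 is estimated at 89%, within 72% to 99%.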

Compound 4, a percentage reported as inhibition, at one concentration (the size of the read-out at that concentration, not a potency): 82.8%
Compound 4: the middle estimate sits 6.2 percentage points above what was measured, within the range that was stated.
By their numbers in this assay, from the lowest: compound 2; then compounds 4 and 1 (each within the scatter of the next); then compound 3.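

In this assay, trichloromethyl in place of (isopropylcarbonyl)oxy on this saturated chain carbon gives no step beyond the scatter (a number 4.1 percentage points lower from compound 1 to compound 4 (within the scatter)), so a group with no hydrogen-bond acceptors can stand here with a read-out in the same range as compound 1. Trichloromethyl in place of hydrogen at this carbon does cost something (a number 15.7 percentage points lower from compound 3 to compound 4 (beyond the scatter)), so the drop from compound 3 seen with compound 1 also appears with a group of quite different atoms. The 2,2,2-trichloroethyl group also reads better than the 1-(((tert-butyl)carbonyl)oxy)ethyl group (a number 17.5 percentage points higher from compound 2 to compound 4 (beyond the scatter)), which leaves compound 2 lowest of the four.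

No measured evidence explains any of these steps. As far as these compounds go, how an amine, a carboxylic acid or a longer chain at this position would read stays open.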